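Acetyl to Carbamoyl at the End of the Chain

The source may hold more compounds than are shown below. What is called first, only, known or untested is meant among the compounds shown, and "the series" means these compounds.

Compound 3 `COc1cccc(Sc2c(NS(=O)(=O)c3ccc(C(C)(C)C)cc3)noc2CCCC(C)=O)c1` was tested in an assay on COS-7 cells for displacement of a labelled ligand from Endothelin receptor type B (Sus scrofa) (a lower number here means a stronger inhibitor, a higher number a weaker inhibitor), where compound 3 gives 400 nM. Among the three compounds measured so far, compound 3 stands second highest. Its nearest neighbour is compound 2 `COc1cccc(Sc2c(NS(=O)(=O)c3ccc(C(C)(C)C)cc3)noc2CCC=O)c1`, which gives 500 nM; the step of a 1.3-fold lower number from compound 2 to compound 3 (0.10 log units; within the scatter) lies within the scatter. The furthest is compound 1 `COc1cccc(Sc2c(NS(=O)(=O)c3ccc(C(C)(C)C)cc3)noc2CCC/C=N/O)c1`, which gives 85 nM; the step of a 4.7-fold higher number from compound 1 to compound 3 (0.67 log units; beyond the scatter) is beyond the scatter, as is a 5.9-fold higher number from compound 1 to compound 2 (0.77 log units; beyond the scatter).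

Compound 4 `COc1cccc(Sc2c(NS(=O)(=O)c3ccc(C(C)(C)C)cc3)noc2CCCC(N)=O)c1` differs from compound 3 by amino in place of methyl on a carbonyl carbon, so that acetyl becomes carbamoyl. Going by the values given here, no measured step exchanges these two groups on a carbonyl carbon. The two steps that touch the same chain end are of unequal size: a 1.3-fold lower number from compound 2 to compound 3 (0.10 log units; within the scatter) stays within the scatter, while a 4.7-fold higher number from compound 1 to compound 3 (0.67 log units; beyond the scatter) shows that this end of the chain can shift the number beyond it. A modest lowering, a 1.6-fold lower number from compound 3 to compound 4 (0.20 log units; within the scatter), is therefore expected rather than a large one. Compound 4 is estimated to give 250 nM, within a range from 70 nM to 900 nM.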

Compound 4, half-maximal inhibitory concentration: 240 nM
Beside the measured number, compound 4's estimate is 1.0-fold (0.02 log units) above it, and the stated range covers the measured number.
By their numbers in this assay, from the lowest: compound 1; then compounds 4, 3 and 2 (each within the scatter of the next, the first and the last beyond it).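

In this assay the exchange of methyl for amino on a carbonyl carbon keeps the heavy atom count and adds one hydrogen-bond donor, yet the step, a 1.7-fold lower number from compound 3 to compound 4 (0.22 log units; within the scatter), cannot be told apart from no change. Compound 4 does separate from the aldehyde end of compound 2, with a 2.1-fold lower number from compound 2 to compound 4 (0.32 log units; beyond the scatter), which compound 3 did not do, though this step only just clears the scatter. The chain end of compound 1 still gives the lowest number, with a 2.8-fold higher number from compound 1 to compound 4 (0.45 log units; beyond the scatter), and no outside data bear on any of these differences.

The compounds shown leave open whether a carboxylic acid or a methyl ester at this chain end would fall with compound 4 or nearer compound 1. They also leave open how a longer chain carrying the carbamoyl group would compare.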